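Compound 3: pyridin-4-yl in place of fluoro

The source may hold more compounds than are shown below. What is called first, only, known or untested is meant among the compounds shown, and "the series" means these compounds.

Compound 1 `Cc1noc(-c2nc(C)c3c(c2N)C(=O)N(Cc2ccccc2)C3=O)n1` gives < 5000 nM in a physicochemical assay for solubility, using the shake flask method, in simulated intestinal fluid, measured as kinetic solubility, with a stated time of 2 h, at 25 degrees C, at pH 6.5 (on this read-out lower numbers stand for lower solubility and higher numbers for higher solubility), as a limit of the assay and not a number. Compound 2 `Cc1noc(-c2nc(C)c3c(c2N)C(=O)N(Cc2ccc(F)cc2)C3=O)n1` gives < 5000 nM in this assay as a limit too. Going by the values given here, the only measured step is a step that the two limits leave unreadable from compound 1 to compound 2 and offers no size to carry forward. Compound 3 `Cc1noc(-c2nc(C)c3c(c2N)C(=O)N(Cc2ccc(-c4ccncc4)cc2)C3=O)n1` has pyridin-4-yl in place of fluoro on an aromatic carbon, para to a large group, with pyridin-4-yl in place of fluoro on an aromatic carbon as the count. No direction can be read from the data, and the expected step is a step that the limit leaves unreadable from compound 2 to compound 3 as a rough figure. Compound 3 is estimated at 3000 nM with an expected range from 1000 nM to 8000 nM in this working note.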

Compound 3, solubility: < 5000 nM
Compound 3 gave a limit, no number (the forecaster's own chance of this, stated with the estimate: 75%); the middle value is on the limit's open side.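

Going by these compounds alone, no step among compound 1, compound 2 and compound 3 can be read in this assay: the limit of < 5000 nM in this assay, at which 3 of the 3 values shown sit.

The compounds shown leave open how the three compare with one another, and whether fluoro or pyridin-4-yl in place of hydrogen shifts this read-out at all.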